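A Methyl Removed from an Ether: What Follows for Compound 3

This account rests on a few compounds, and the source may have more. Where it says the series, first, only, none or still open, it means among the compounds named here.

Measured so far:
compound 1, `Cc1cc(O)cc(-c2nn(CC#N)cc2-c2ccnc(-c3ccc(Oc4ccccc4)cc3)c2)c1`, gives 90%
compound 2, `COc1cc(C)cc(-c2nn(CC#N)cc2-c2ccnc(-c3ccc(N(C)C)cc3)c2)c1`, gives 92%

Both compounds were run in a functional assay on CAKI-1 cells (Homo sapiens) for cytotoxicity, read by sulforhodamine B assay, with a stated time of 48 h, tested at 0.01 uM; on this read-out higher numbers stand for a weaker effect at the one concentration tested and lower numbers for a stronger effect. Compound 2 carries the larger of the two figures, yet its gap to compound 1 lies within the usual scatter, so the two cannot be told apart on these numbers; both leave most cells untouched at the concentration used.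

Compound 3, `Cc1cc(O)cc(-c2nn(CC#N)cc2-c2ccnc(-c3ccc(N(C)C)cc3)c2)c1`, has not yet been measured. It differs from compound 2 in one place: hydrogen in place of methyl on an oxygen on an aromatic ring. Compound 1 already carries a hydroxy group at this position, and in this assay compound 1 gives 90%, close to compound 2. The step is therefore expected to be none beyond the scatter: a number 2 percentage points lower from compound 2 to compound 3 (within the scatter). Compound 3 is estimated at 90%, with a likely range from 80% to 100%.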

Compound 3, a percentage reported as activity, at one concentration (the size of the read-out at that concentration, not a potency): 102%
Beside the measured number, compound 3's estimate is 12 percentage points below it, and the stated range ends below it.
By their numbers in this assay, from the lowest: compounds 1, 2 and 3 (each within the scatter of the next, the first and the last beyond it).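

In this assay, hydrogen in place of methyl on the oxygen gives a number 10 percentage points higher from compound 2 to compound 3 (within the scatter), so with the dimethylamino group held fixed, the change from methoxy to hydroxy cannot be told apart from ordinary repeat-to-repeat variation. With the hydroxy group held fixed, dimethylamino in place of phenoxy gives a number 12 percentage points higher from compound 1 to compound 3 (beyond the scatter), a modest step toward a weaker effect and the only one in this set that clears the scatter, so in this small set the phenoxy-to-dimethylamino change registers where the methyl-to-hydrogen change on the oxygen does not. Nothing available here explains either step.

Still open, as far as these compounds go, is whether a longer chain on that oxygen, such as ethoxy, or an amine in place of the hydroxy group would shift the number. From the compounds shown here alone, it is also open whether these steps would hold at a higher test concentration, where the compounds might show a clearer effect on the cells.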